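The source may hold more compounds than are shown below. What is called first, only, known or untested is meant among the compounds shown, and "the series" means these compounds.

Working notes on the series. All three measured members share one core and differ only in the group on the amide-type nitrogen. Compound 1 `C=CC1=C(C(=O)NCc2ccccc2)C(c2ccc(OC)cc2)OC1` carries benzyl there; in a functional assay on A549 cells (Homo sapiens) for cytotoxicity, read by MTT assay, with a stated time of 24 h (on this read-out lower numbers stand for stronger inhibition and higher numbers for weaker inhibition), compound 1 gives > 100000 nM, which is a limit of the assay and not a number. Compound 2 `C=CC1=C(C(=O)NC(C)(C)C)C(c2ccc(OC)cc2)OC1` carries tert-butyl; in this assay compound 2 gives > 100000 nM, again a limit. Compound 3 `C=CC1=C(C(=O)Nc2ccccc2)C(c2ccc(OC)cc2)OC1` carries phenyl; in this assay compound 3 gives > 100000 nM, also a limit. The steps a step that the two limits leave unreadable from compound 1 to compound 2, a step that the two limits leave unreadable from compound 1 to compound 3 and a step that the two limits leave unreadable from compound 2 to compound 3 therefore cannot be sized, because of the limit of > 100000 nM in this assay, at which 3 of the 3 values shown sit. Compound 3 thus stands where every measured member stands, at the limit, with no readable ordering among them.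

Compound 4 `C=CC1=C(C(=O)NCc2ccc(Cl)cc2)C(c2ccc(OC)cc2)OC1` differs from compound 3 by 4-chlorobenzyl in place of phenyl on an amide-type nitrogen. The nearest measured comparison is the reverse of a step that the two limits leave unreadable from compound 1 to compound 3, which is unreadable, so no step beyond the scatter can be anticipated in either direction in this assay. Compound 4 is expected to sit at the limit as well, estimated at 150000 nM with a range from 40000 nM to 600000 nM. The expected step that the limit leaves unreadable from compound 3 to compound 4 is accordingly estimated as none beyond the scatter.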

Compound 4, half-maximal inhibitory concentration: > 100000 nM
Compound 4 ended at the assay's limit; the forecaster's own chance of this, stated with the estimate: 85%; the middle value is on the limit's open side.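

The steps to compound 4 from compound 1, compound 2 and compound 3 cannot be read in this assay, because all four compounds stand at a limit and give no number: the limit of > 100000 nM in this assay, at which 4 of the 4 values shown sit.

The compounds shown leave open whether benzyl, tert-butyl, phenyl and 4-chlorobenzyl on the amide-type nitrogen differ at all in this assay.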